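This account rests on a few compounds, and the source may have more. Where it says the series, first, only, none or still open, it means among the compounds named here.

Measured compounds:
compound 1 `N#Cc1ccc(Nc2nc(Oc3ccnc4ccccc34)nc(N3CCN(c4ccccc4Cl)CC3)n2)cc1C(F)(F)F` — 92600 nM
compound 2 `CC(=O)N1CCN(c2nc(Nc3ccc(C#N)c(C(F)(F)F)c3)nc(Oc3ccnc4ccccc34)n2)CC1` — 75100 nM
compound 3 `CN1CCN(c2nc(Nc3ccc(C#N)c(C(F)(F)F)c3)nc(Oc3ccnc4ccccc34)n2)CC1` — 51200 nM

All three share one core and differ only in the group on an amine nitrogen in a ring. In a functional assay on DU-145 cells (Homo sapiens) for cytotoxicity, read by sulforhodamine B assay, with a stated time of 48 h (a lower number here means a stronger inhibitor of growth, a higher number a weaker inhibitor of growth), compound 2 gives 75100 nM, the second highest of the three numbers, but its gap to either neighbour is within the scatter, so no order among them can be read.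

Compound 4 `N#Cc1ccc(Nc2nc(Oc3ccnc4ccccc34)nc(N3CCN(c4ccccn4)CC3)n2)cc1C(F)(F)F` is the next step: pyridin-2-yl in place of acetyl on an amine nitrogen in a ring. For the measured compounds named here, two measured steps bear on it. The change from compound 1 to compound 2 replaced an aromatic ring on that nitrogen with acetyl and gave a 1.2-fold lower number from compound 1 to compound 2 (0.09 log units; within the scatter); the change from compound 1 to compound 3 gave a 1.8-fold lower number from compound 1 to compound 3 (0.26 log units; within the scatter); the step from compound 2 to compound 3 gave a 1.5-fold lower number from compound 2 to compound 3 (0.17 log units; within the scatter). None of these left the scatter, so putting an aromatic ring back on that nitrogen is not expected to move this assay beyond the scatter either.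

Compound 4 is therefore estimated at 80000 nM, with a likely range of 35000 nM to 180000 nM, meaning an expected step of a 1.1-fold higher number from compound 2 to compound 4 (0.03 log units; within the scatter).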

Compound 4, concentration for 50% growth inhibition: 85900 nM
Compound 4: middle estimate off by 1.1-fold (0.03 log units), on the low side, and the stated range covers the measured number.
By their numbers in this assay, from the lowest: compounds 3, 2, 4 and 1 (each within the scatter of the next).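

In this assay, a pyridin-2-yl group on the amine nitrogen now joins the comparison, and replacing acetyl with it gives a 1.1-fold higher number from compound 2 to compound 4 (0.06 log units; within the scatter), while replacing methyl with it gives a 1.7-fold higher number from compound 3 to compound 4 (0.22 log units; within the scatter). The comparison between the two aromatic groups gives a 1.1-fold lower number from compound 1 to compound 4 (0.03 log units; within the scatter), so all six pairwise steps among these four compounds now lie within the scatter, including this swap of 2-chlorophenyl for a six-membered aromatic ring with a ring nitrogen. No independent measurement is available to explain why these groups give such similar numbers.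

The compounds shown leave open whether a carboxylic acid, a primary amine or a longer chain on that nitrogen would move the number beyond the scatter. They also leave open whether a change elsewhere on the shared core would do so.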